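Swapping the Ring Nitrogen Substituent in a Sulfonamide Series

A few compounds are considered here, and "the series" means these few. Any claim that something is new, unique, unknown or untested is made for them only; others in the source may bear on it.

Measured compounds:
Compound 1, `CC(C)N1C(=O)COc2ccc(-c3cnc(Cl)c(NS(=O)(=O)c4ccc(F)cc4)c3)cc21`, gives 18900 nM.
Compound 2, `O=C1COc2ccc(-c3cnc(Cl)c(NS(=O)(=O)c4ccc(F)cc4)c3)cc2N1c1ccc(Cl)cc1`, gives 27900 nM.
Compound 3, `COc1ncc(-c2ccc3c(c2)N(c2ccc(Cl)cc2)C(=O)CO3)cc1NS(=O)(=O)c1ccc(F)cc1`, gives 19200 nM.

All three were tested in a functional assay on HCT-116 cells (Homo sapiens) for antiproliferative activity, read by MTT assay, with a stated time of 72 h; a lower number here means a stronger inhibitor, a higher number a weaker inhibitor. The three numbers sit close together, and no ordering among them can be claimed, since every step between them is within the usual scatter.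

Compound 2 and compound 1 differ by a single change, (isopropyl in place of 4-chlorophenyl on an amide-type nitrogen in a ring), and this change made a step of a 1.5-fold lower number from compound 2 to compound 1 (0.17 log units; within the scatter). Compound 2 and compound 3 differ in another place, (methoxy in place of chloro on an aromatic carbon), with a step of a 1.5-fold lower number from compound 2 to compound 3 (0.16 log units; within the scatter).

Compound 4, `COc1ncc(-c2ccc3c(c2)N(C(C)C)C(=O)CO3)cc1NS(=O)(=O)c1ccc(F)cc1`, has not yet been measured. Among the measured compounds shown here, it differs from compound 3 by isopropyl in place of 4-chlorophenyl on an amide-type nitrogen in a ring, which is the same change as the one from compound 2 to compound 1, made on a core that carries the methoxy group instead of chloro. Because the earlier step was a 1.5-fold lower number from compound 2 to compound 1 (0.17 log units; within the scatter), the expectation is that the same change on compound 3 gives a step of roughly similar size, namely a 1.4-fold lower number from compound 3 to compound 4 (0.14 log units; within the scatter), still within the scatter. On this basis compound 4 is estimated to give 14000 nM in this assay, with an expected range from 5000 nM to 40000 nM.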

Compound 4, half-maximal inhibitory concentration: 19200 nM
Compound 4: middle estimate off by 1.4-fold (0.14 log units), on the low side; the measured number falls inside the stated range.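

In this assay, isopropyl in place of 4-chlorophenyl on the amide-type nitrogen in the ring, now on the core carrying methoxy, gives no change at the digits printed from compound 3 to compound 4 (within the scatter), and set beside the same change on the core carrying chloro, the comparison reads: the same change on two cores in this assay, a 1.5-fold lower number (0.17 log units; within the scatter) from compound 2 to compound 1 and no change at the digits printed (within the scatter) from compound 3 to compound 4, 1.5-fold (0.17 log units) apart, within the scatter of two such steps. The second change, methoxy in place of chloro on an aromatic carbon, now made on the compounds carrying isopropyl, gives a 1.0-fold higher number from compound 1 to compound 4 (0.01 log units; within the scatter), and the comparison with its earlier step reads: the same change on two cores in this assay, a 1.5-fold lower number (0.16 log units; within the scatter) from compound 2 to compound 3 and a 1.0-fold higher number (0.01 log units; within the scatter) from compound 1 to compound 4, 1.5-fold (0.17 log units) apart, within the scatter of two such steps. These four compounds therefore show no detectable difference in how either change behaves on the two cores, but they do not prove that the changes carry over reliably, since every step here is within the scatter and a real but small effect, or a small dependence on the core, could stay hidden.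

The compounds shown leave open whether a different group on the amide-type nitrogen, such as a longer chain or a carboxylic acid, would produce a step beyond the scatter. They also leave open whether an amine or a nitrile in place of the chloro or methoxy would do so, and whether any such step would then hold from one core to the other.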